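Removal of the ring amino group on the aryl substituent

The source may hold more compounds than are shown below. What is called first, only, known or untested is meant among the compounds shown, and "the series" means these compounds.

Of the compounds shown here, two have been measured in an assay for binding affinity to adenosine receptor A1 (Bos taurus); a higher number here means a weaker inhibitor, a lower number a stronger inhibitor. Compound 1 `CSc1ccc(-c2nc3c(=O)n(C)c(=O)n(C)c3[nH]2)cc1` gives 2 nM there. Compound 2 `Cn1c(=O)c2nc(-c3ccc([N+](=O)[O-])cc3N)[nH]c2n(C)c1=O` gives 2.5 nM, the higher of the two numbers, yet the gap to compound 1 lies within the scatter, so the two compounds cannot be told apart on these numbers.

Compound 3 `Cn1c(=O)c2nc(-c3ccc([N+](=O)[O-])cc3)[nH]c2n(C)c1=O` has not been measured. It differs from compound 2 in one place: hydrogen in place of amino on an aromatic carbon, ortho to a large group and meta to a nitro group. Going by the values given here, no measured pair shows this change, so there is no step to lean on. The expectation for this change is a step of no more than modest size, tending to a weaker inhibitor, estimated as a 1.6-fold higher number from compound 2 to compound 3 (0.20 log units; within the scatter). The value expected for compound 3 in this assay is 4 nM, within a range of 1 nM to 15 nM.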

Compound 3, half-maximal inhibitory concentration: 8 nM
The estimate for compound 3 lay 2.0-fold (0.30 log units) below the measured number; low and high end bracket the measured number.
By their numbers in this assay, from the lowest: compounds 1 and 2 (each within the scatter of the next); then compound 3.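

In this assay the amino group ortho to a large group and meta to a nitro group is not neutral to lose: hydrogen in its place gives a 3.2-fold higher number from compound 2 to compound 3 (0.51 log units; beyond the scatter) and thus a real, though modest, loss of strength. Without that amino group, nitro no longer matches methylsulfanyl on the aromatic carbon, with nitro in place of methylsulfanyl giving a 4.0-fold higher number from compound 1 to compound 3 (0.60 log units; beyond the scatter) as a step of similar modest size. No available measurement gives a reason for either step.

On these data alone, it remains open whether a hydroxyl or a methylamino group on the same aromatic carbon would behave like amino or like hydrogen. As far as these compounds go, it is also open whether amino at that carbon would bring a similar step in a compound carrying methylsulfanyl instead of nitro.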